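Aryl in place of styryl at the saturated ring carbon

A few compounds are considered here, and "the series" means these few. Any claim that something is new, unique, unknown or untested is made for them only; others in the source may bear on it.

Working notes on the pair sharing the core of compound 1, `Cc1cc(O)c(C2=NN(c3ccc(S(N)(=O)=O)cc3)C(c3ccccc3Cl)C2)cc1Cl`. In a functional assay on MDA-MB-468 cells (Homo sapiens) for antiproliferative activity, with a stated time of 48 h (on this read-out higher numbers stand for weaker inhibition of growth and lower numbers for stronger inhibition of growth), compound 1 gives 4740 nM, and compound 2, `Cc1cc(O)c(C2=NN(c3ccc(S(N)(=O)=O)cc3)C(/C=C/c3ccccc3)C2)cc1Cl`, gives 13800 nM. On these two numbers compound 2 stands highest, with compound 1 the nearest and only comparison. Going by the values given here, the single measured step is a 2.9-fold higher number from compound 1 to compound 2 (0.46 log units; beyond the scatter).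

Compound 3 is `COc1ccc(C2CC(c3cc(Cl)c(C)cc3O)=NN2c2ccc(S(N)(=O)=O)cc2)cc1OC`. Relative to compound 2 the change is 3,4-dimethoxyphenyl in place of 2-phenylethenyl on a saturated ring carbon. Among the compounds with values here, the one step that bears on this is a 2.9-fold higher number from compound 1 to compound 2 (0.46 log units; beyond the scatter), where an aryl group at the same saturated ring carbon was replaced by the styryl group and the number rose beyond the scatter. Within the data shown here, compound 3 restores an aryl group at that carbon, so the return is expected to run in the opposite direction, though no measured pair tells how a dimethoxyphenyl group compares with a chlorophenyl group there. For compound 3 the expected step is a 2.3-fold lower number from compound 2 to compound 3 (0.36 log units; beyond the scatter) in this assay. The estimate for compound 3 in this assay is 6000 nM, with a range from 2500 nM to 15000 nM.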

Compound 3, concentration for total growth inhibition: 9510 nM
Compound 3: the middle estimate sits 1.6-fold (0.20 log units) below what was measured, within the range that was stated.
By their numbers in this assay, from the lowest: compounds 1, 3 and 2 (each within the scatter of the next, the first and the last beyond it).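

In this assay, putting 3,4-dimethoxyphenyl on the saturated ring carbon in place of 2-phenylethenyl gives a 1.5-fold lower number from compound 2 to compound 3 (0.16 log units; within the scatter), and putting it there in place of 2-chlorophenyl gives a 2.0-fold higher number from compound 1 to compound 3 (0.30 log units; within the scatter), so compound 3 cannot be told apart from either of the other two compounds. The earlier separation, a 2.9-fold higher number from compound 1 to compound 2 (0.46 log units; beyond the scatter), therefore does not extend to aryl groups in general: of the two aryl groups shown, only 2-chlorophenyl stands beyond the scatter from 2-phenylethenyl, and compound 3 goes against any rule that an aryl group at this carbon beats the styryl group. No measured evidence on the cause of these differences is available here.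

Going by these compounds alone, with only three compounds, the position remains thinly mapped, and the small steps to compound 3 leave the order among aryl groups unsettled. Still open, as far as these compounds go, is where an unsubstituted phenyl, a 4-dimethylaminophenyl, a 4-carboxyphenyl or a saturated 2-phenylethyl chain at this carbon would fall relative to compound 1 and compound 2 on the shared core.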